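The source may report more compounds than this note shows. Statements on the series, on what has been measured and on what is new or still open speak of the compounds shown alone.

Measured compounds:
Compound 1, `CCCCCC(CCO)n1cnc2c(Cl)nc(F)nc21`, 7440 nM
Compound 2, `CCCCCCC(CCO)n1cnc2c(Cl)nc(F)nc21`, 12900 nM
Compound 3, `CCCCCCCCCC(CCO)n1cnc2c(Cl)ncnc21`, 1150 nM

Notes on the series. The read-out throughout is a functional assay on SW480 cells (Homo sapiens) for antiproliferative activity, read by MTT assay, with a stated time of 48 h; a lower number here means a stronger inhibitor, a higher number a weaker inhibitor. Compound 1 gives 7440 nM in this assay, and compound 2 gives 12900 nM. The two differ by methyl in place of hydrogen on a saturated chain carbon, six bonds along the chain from an aromatic nitrogen; the step of a 1.7-fold higher number from compound 1 to compound 2 (0.24 log units; within the scatter) is within the scatter, so no order between compound 1 and compound 2 is claimed. Compound 3 carries a different core and a longer chain; how the core of compound 3 differs from the core of compound 1 is not broken down here. In this assay compound 3 gives 1150 nM, which stands beyond the scatter from both compound 1 and compound 2.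

Compound 4, `CCCCCCCCCCC(CCO)n1cnc2c(Cl)ncnc21`, is not yet measured. It differs from compound 3 by methyl in place of hydrogen on a saturated chain carbon, ten or more bonds along the chain from an aromatic nitrogen. For the measured compounds named here, this is the same kind of change as the one from compound 1 to compound 2, though the methyl enters at a different place along the chain. Going by the values given here, the only measured example of this kind of change, the step of a 1.7-fold higher number from compound 1 to compound 2 (0.24 log units; within the scatter), stayed within the scatter. On that basis the step expected for compound 4 is a 1.4-fold higher number from compound 3 to compound 4 (0.14 log units; within the scatter), a step of about the same size, because compound 3 already sits at 1150 nM and the earlier methyl shifted little. Compound 4 is therefore estimated at 1600 nM in this assay, expected to fall between 600 nM and 4500 nM.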

Compound 4, half-maximal inhibitory concentration: 3160 nM
Estimate against measurement, compound 4: 2.0-fold (0.30 log units) below; measured number inside the range.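

In this assay, methyl in place of hydrogen on a saturated chain carbon, ten or more bonds along the chain from an aromatic nitrogen, gives a 2.7-fold higher number from compound 3 to compound 4 (0.44 log units; beyond the scatter), a modest step on the core of compound 3. Set beside the same kind of change on the core of compound 1, the step does not differ measurably, even though only the later step lies beyond the scatter: the same change on two cores in this assay, a 1.7-fold higher number (0.24 log units; within the scatter) from compound 1 to compound 2 and a 2.7-fold higher number (0.44 log units; beyond the scatter) from compound 3 to compound 4, 1.6-fold (0.20 log units) apart, within the scatter of two such steps This supports carrying the change across these two cores with a step of similar size, but it does not show a fixed size for the step on every core or at every chain length, as it rests on two pairs only and the methyl enters at a different place along the chain in each pair.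

The compounds shown leave open how much of the gap between the two cores belongs to the core and how much to the chain, as no single pair isolates either one: a longer chain on the core of compound 1 and a shorter chain on the core of compound 3 would separate them. Also open, from the compounds shown here alone, is how either core responds to an amine or a carboxylic acid in place of the hydroxyl.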